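From Methoxy to Phenoxy: Expected Potency of Compound 4

A few compounds are considered here, and "the series" means these few. Any claim that something is new, unique, unknown or untested is made for them only; others in the source may bear on it.

Compound 3 `COc1cc(C#Cc2ccc(CCC(=O)O)cc2)ccn1` gives 525 nM in an in vitro functional assay on 1321-N1 cells for agonist activity at Free fatty acid receptor 1 (Homo sapiens), read by fluorescence, spectrophotometry and calcium flux (a higher number here means that more compound is needed for the effect, a lower number that less compound is needed), the highest of the three numbers measured. Compound 1 `O=C(O)CCc1ccc(C#Cc2ccnc(F)c2)cc1` gives 513 nM, within the scatter of compound 3, while compound 2 `Cc1c(C#Cc2ccc(CCC(=O)O)cc2)cc(Cl)nc1Cl` gives 43.7 nM, a lower number beyond it. Going by the values given here, the only single-place step, a 1.0-fold higher number from compound 1 to compound 3 (0.01 log units; within the scatter), changed nothing. Compound 4 `O=C(O)CCc1ccc(C#Cc2ccnc(Oc3ccccc3)c2)cc1` differs from compound 3 by phenyl in place of methyl on an oxygen on an aromatic ring. Among the compounds with values here, no measured step tests a methyl-to-phenyl exchange on that oxygen; the fluoro-to-methoxy step at the same place lay within the scatter, which suggests only that this position tolerates change. The estimated step for compound 4 is a 1.1-fold lower number from compound 3 to compound 4 (0.02 log units; within the scatter), expected to stay within the usual scatter. The expected value for compound 4 is 500 nM, with a range from 150 nM to 1600 nM.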

Compound 4, half-maximal effective concentration: 479 nM
Compound 4: the middle estimate sits 1.0-fold (0.02 log units) above what was measured, and the stated range covers the measured number.
By their numbers in this assay, from the lowest: compound 2; then compounds 4, 1 and 3 (each within the scatter of the next).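

In this assay, phenyl in place of methyl on the oxygen gives a 1.1-fold lower number from compound 3 to compound 4 (0.04 log units; within the scatter), so this place accepts a whole aromatic ring as readily as a single carbon. Set against the fluoro compound, phenoxy gives a 1.1-fold lower number from compound 1 to compound 4 (0.03 log units; within the scatter), which means fluoro, methoxy and phenoxy on this aromatic carbon all read alike despite their difference in size. No evidence shown here bears on this result. As far as these compounds go, it remains open whether a substituted phenoxy, such as one carrying a chloro or a carboxylic acid, would keep this reading. An amine or a longer chain at this place is equally untested by the compounds shown.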